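Amide swap from compound 2 to compound 4

The compounds below may be only part of what the source reports. "The series", "measured", "known", "first", "only" and "open" are said of these compounds alone.

Compound 2 `O=C(c1ccccc1F)N1CC(c2nc(-c3cccc(Cl)c3)no2)C1` is measured in an assay on HEK293 cells for positive allosteric modulation of metabotropic glutamate receptor 5 (Homo sapiens), read by FLIPR; on this read-out lower numbers stand for an effect already at smaller amounts and higher numbers for an effect only at larger amounts of compound. In this assay compound 2 gives only a limit, > 10000 nM. Compound 1 `Cc1cccc(-c2noc(C3CN(C(=O)c4ccccc4F)C3)n2)c1` also gives only a limit, > 10000 nM. The step that the two limits leave unreadable from compound 1 to compound 2 therefore cannot be read because both sit at the limit of > 10000 nM in this assay, at which 2 of the 3 values shown sit. Within the data shown here, compound 3 `O=C(C1CCC(F)(F)CC1)N1CC(c2nc(-c3cccc(F)c3)no2)C1` gives 520 nM in this assay; it differs from compound 2 both on the carbonyl carbon and in the halogen on an aromatic carbon, so it shows only that a member of this series with a non-aromatic ring on the carbonyl carbon can give a number rather than a limit.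

Compound 4 `O=C(C1CCCO1)N1CC(c2nc(-c3cccc(Cl)c3)no2)C1` differs from compound 2 in one place: oxolan-2-yl in place of 2-fluorophenyl on a carbonyl carbon. Among the measured compounds shown here, no measured step covers this change, and the single measured step lies elsewhere and is unreadable. Since compound 3 supplies the only number shown, a measurable effect is expected for compound 4, but its size is uncertain and a limit remains possible. The estimate for compound 4 is 3000 nM, with a range of 800 nM to 10000 nM. This corresponds to an expected step of an at least 3.3-fold lower number from compound 2 to compound 4 (0.52 log units; beyond the scatter).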

Compound 4, half-maximal effective concentration: > 10000 nM
Compound 4: a limit, no number (the forecaster's own chance of this, stated with the estimate: 40%); middle value at least 3.3-fold (0.52 log units) away from the limit.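

The step from compound 2 to compound 4 cannot be read, because both compounds give only a limit and no number: the limit of > 10000 nM in this assay, at which 3 of the 4 values shown sit. The compounds shown leave open how oxolan-2-yl and 2-fluorophenyl on a carbonyl carbon compare in this assay.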